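Swapping carbonyl for sulfonyl on a shared core

The source may report more compounds than this note shows. Statements on the series, on what has been measured and on what is new or still open speak of the compounds shown alone.

Measured so far in a functional assay on KB cells (Homo sapiens) for antiproliferative activity, read by MTT assay, with a stated time of 72 h; a higher number here means a weaker inhibitor, a lower number a stronger inhibitor
- compound 1 `CCC(=O)N(C)c1ccc2[nH]c(-c3n[nH]c4ccccc34)cc2n1` gives 9300 nM
- compound 2 `CN(C(=O)c1ccc(Br)cc1)c1ccc2[nH]c(-c3n[nH]c4ccccc34)cc2n1` gives 1780 nM

Compound 2 holds the lower of the two numbers (1780 nM), which makes it the stronger inhibitor of the pair. The next compound, compound 3 `Cc1ccc(S(=O)(=O)N(C)c2ccc3[nH]c(-c4n[nH]c5ccccc45)cc3n2)cc1`, has (4-methylphenyl)sulfonyl in place of (4-bromophenyl)carbonyl on a nitrogen on an aromatic ring. Within the data shown here, only one measured step offers any guidance (a 5.2-fold lower number from compound 1 to compound 2 (0.72 log units; beyond the scatter)). It is modest, and it put 4-bromophenyl in place of ethyl on a carbonyl carbon. Among the measured compounds shown here, compound 3 keeps a six-membered aromatic ring of carbon only, but no measured step exchanges a carbonyl for a sulfonyl. No step beyond the scatter is therefore expected in this assay, and the uncertainty is wide. The estimated change is small (a 1.4-fold higher number from compound 2 to compound 3 (0.15 log units; within the scatter)). Compound 3 is estimated at 2500 nM (expected range 600 nM to 10000 nM).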

Compound 3, half-maximal inhibitory concentration: 9500 nM
Compound 3: the middle estimate sits 3.8-fold (0.58 log units) below what was measured; low and high end bracket the measured number.
By their numbers in this assay, from the lowest: compound 2; then compounds 1 and 3 (each within the scatter of the next).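

In this assay the swap at this nitrogen gives a 5.3-fold higher number from compound 2 to compound 3 (0.73 log units; beyond the scatter), so the lower number of compound 2 is lost even though a six-membered aromatic ring of carbon only stays in place. Measured against propanoyl, the new group gives a 1.0-fold higher number from compound 1 to compound 3 (0.01 log units; within the scatter), which leaves the two level, so an aromatic ring on this nitrogen does not by itself bring the lower number. Nothing available explains why these groups behave as they do.

This swap changed two things at once, carbonyl to sulfonyl and bromine to methyl, so the compounds shown cannot tell which of them matters. A (4-bromophenyl)sulfonyl or a (4-methylphenyl)carbonyl group on the same nitrogen would separate the two changes.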